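From compound 2 to compound 3: a halophenyl swap

This account rests on a few compounds, and the source may have more. Where it says the series, first, only, none or still open, it means among the compounds named here.

Values in an ADME assay on MT4 cells (Homo sapiens) for cytotoxicity, read by MTT assay, with a stated time of 4 days (a higher number here means that more compound is tolerated, a lower number that less compound is tolerated), for the series so far
compound 1 `O=C(COc1cccc2ccccc12)N/N=C/c1ccccc1Br` gives 11.4 ug/mL
compound 2 `O=C(COc1cccc2ccccc12)N/N=C/c1ccc(Br)cc1` gives 106 ug/mL
compound 3 `O=C(COc1cccc2ccccc12)N/N=C/c1ccccc1Cl` has no value yet

Among the measured compounds shown here, compound 2 at 106 ug/mL is the higher of the two measured compounds, and its only neighbour is compound 1. The next change leads to compound 3 and is 2-chlorophenyl in place of 4-bromophenyl on a carbon with a double bond to nitrogen in short, 2-chlorophenyl in place of 4-bromophenyl on a carbon with a double bond to nitrogen. For the measured compounds named here, one measured step bears on it. That step is a 9.3-fold higher number from compound 1 to compound 2 (0.97 log units; beyond the scatter) and it is modest, yet beyond the scatter, with 4-bromophenyl in place of 2-bromophenyl. Compound 3 gives up the same 4-bromophenyl, and its 2-chlorophenyl matches the 2-bromophenyl of compound 1 in number, though not in halogen. Going by the values given here, no measured step covers a change of bromine to chlorine, and the whole argument rests on one pair. A lower number is therefore expected in this assay with a size close to that measured step, read in reverse. The expected step is a 7.6-fold lower number from compound 2 to compound 3 (0.88 log units; beyond the scatter) on this reasoning. For compound 3 the estimate is 14 ug/mL with an expected range from 5 ug/mL to 45 ug/mL on this reading.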

Compound 3, half-maximal cytotoxic concentration: 56.2 ug/mL
Beside the measured number, compound 3's estimate is 4.0-fold (0.60 log units) below it; the measured number lies above the stated range.
By their numbers in this assay, from the lowest: compound 1; then compounds 3 and 2 (each within the scatter of the next).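

In this assay, the low number of compound 1 no longer reads as a general result of moving the halogen away from the 4-bromophenyl arrangement: a 1.9-fold lower number from compound 2 to compound 3 (0.28 log units; within the scatter), so 2-chlorophenyl and 4-bromophenyl are not separated at this carbon with a double bond to nitrogen. The halogen itself now counts, since chloro in place of bromo on an aromatic carbon gives a 4.9-fold higher number from compound 1 to compound 3 (0.69 log units; beyond the scatter), and of the three compounds only compound 1, with its 2-bromophenyl, stands apart from the other two beyond the scatter. Nothing available explains why this one combination of halogen and ring placement gives the lowest number in the series.

Still open, as far as these compounds go, is whether 4-chlorophenyl would stay with compound 2 and compound 3 or whether chloro in place of bromo also matters there, which would show if the halogen effect belongs only to the 2-substituted ring. Equally open, from the compounds shown here alone, is where a 2-fluorophenyl, a 2-methoxyphenyl or a phenyl carrying an amine would fall at this carbon, and whether the gap around compound 1 survives on any core other than the shared one.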